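Moving the Pyridine Nitrogen on a Second Core

The source may hold more compounds than are shown below. What is called first, only, known or untested is meant among the compounds shown, and "the series" means these compounds.

Of the compounds shown here, three have so far been measured in a functional assay on QGY-7703 cells (Homo sapiens) for cytotoxicity, read by MTT assay, with a stated time of 24 h; on this read-out higher numbers stand for weaker inhibition and lower numbers for stronger inhibition. In this assay compound 1 `CN1C/C(=C\c2cccnc2)C(=O)/C(=C/c2ccccc2C(F)(F)F)C1` gives 2910 nM. Compound 2 `CN1C/C(=C\c2ccncc2)C(=O)/C(=C/c2ccccc2C(F)(F)F)C1` differs from it in one place, (pyridin-4-yl in place of pyridin-3-yl on a double-bonded chain carbon bound to a double-bonded ring carbon), and in this assay compound 2 gives 4500 nM; the step is a 1.5-fold higher number from compound 1 to compound 2 (0.19 log units; within the scatter), so the two values cannot be told apart with confidence. Compound 3 `O=C1/C(=C/c2cccnc2)CNC/C1=C\c1ccccc1F` belongs to a different core, and how its core differs from that of compound 1 is not broken down here. In this assay compound 3 gives 8890 nM, the highest of the three numbers, within the scatter of compound 2 but beyond it relative to compound 1.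

Compound 4 `O=C1/C(=C/c2ccncc2)CNC/C1=C\c1ccccc1F` has not yet been measured. It stands to compound 3 exactly as compound 2 stands to compound 1: the change is pyridin-4-yl in place of pyridin-3-yl on a double-bonded chain carbon bound to a double-bonded ring carbon, and the place is described in the same words both times, so it is the same change on a second core. Among the measured compounds shown here, since the one earlier instance, a 1.5-fold higher number from compound 1 to compound 2 (0.19 log units; within the scatter), stayed within the scatter, the step from compound 3 to compound 4 is expected to be of similar size, a 1.5-fold higher number from compound 3 to compound 4 (0.17 log units; within the scatter). On that basis compound 4 is estimated to give 13000 nM in this assay, with a likely range from 6000 nM to 30000 nM.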

Compound 4, half-maximal inhibitory concentration: 14200 nM
Compound 4: the middle estimate sits 1.1-fold (0.04 log units) below what was measured, and the stated range covers the measured number.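

On the second core, in this assay, pyridin-4-yl in place of pyridin-3-yl gives a 1.6-fold higher number from compound 3 to compound 4 (0.20 log units; within the scatter), and this step can be set directly beside its counterpart on the first core: the same change on two cores in this assay, a 1.5-fold higher number (0.19 log units; within the scatter) from compound 1 to compound 2 and a 1.6-fold higher number (0.20 log units; within the scatter) from compound 3 to compound 4, 1.0-fold (0.01 log units) apart, within the scatter of two such steps. Within these four compounds, then, the change carries over from the core of compound 1 to the core of compound 3 with a step of the same size, and neither pair goes against that agreement. Each step on its own lies within the scatter, however, so it is not shown that pyridin-4-yl and pyridin-3-yl truly differ in this read-out, and two cores cannot establish that the change would behave the same way on any further core in the series.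

The compounds shown carry only pyridin-3-yl and pyridin-4-yl on the double-bonded chain carbon, so it remains open how a pyridin-2-yl or a plain phenyl group would compare in that place. Also open, going by these compounds, is whether the two steps would still agree with a methoxy group or a nitrile on the other aromatic ring, in place of the trifluoromethyl or fluoro substituent present there now.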